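Pyrazolyl for pyridyl in the anilinonitrile series

The compounds below may be only part of what the source reports. "The series", "measured", "known", "first", "only" and "open" are said of these compounds alone.

In a functional assay on CWR22R cells (Homo sapiens) for antiproliferative activity, read by CCK-8 assay, with a stated time of 6 days (a higher number here means a weaker inhibitor, a lower number a stronger inhibitor), compound 1 `CCN(c1ccc(C#N)c(Cl)c1)c1cc(-c2cccnc2)ccc1C` gives 2000 nM. Compound 2 `N#Cc1ccc(N2CCCc3c(-c4ccncc4)cccc32)cc1C(F)(F)F`, built on a different core, gives 15000 nM in this assay; of the two numbers compound 1 holds the lower one, and the gap to compound 2 lies beyond the scatter. Compound 3 `CCN(c1ccc(C#N)c(Cl)c1)c1cc(-c2ccnn2C)ccc1C` has not yet been measured. It differs from compound 1 at a single site, (1-methyl-1H-pyrazol-5-yl in place of pyridin-3-yl on an aromatic carbon). Going by the values given here, no measured pair isolates this change, so nothing in the data fixes its direction or size. The expectation is therefore anchored on compound 1 with its value of 2000 nM, and the step of a 1.5-fold higher number from compound 1 to compound 3 (0.18 log units; within the scatter) is expected to be small, a modest loss or none beyond the scatter. Compound 3 is accordingly expected to give 3000 nM, with a range from 800 nM to 12000 nM that reflects the absence of a matched precedent.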

Compound 3, half-maximal inhibitory concentration: 4330 nM
The estimate for compound 3 lay 1.4-fold (0.16 log units) below the measured number, within the range that was stated.
By their numbers in this assay, from the lowest: compound 1; then compound 3; then compound 2.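

In this assay, going by these compounds alone, the change to 1-methyl-1H-pyrazol-5-yl in place of pyridin-3-yl gives the first matched step at this position, a modest loss (a 2.2-fold higher number from compound 1 to compound 3 (0.34 log units; beyond the scatter)). The step lies beyond the scatter, so this site, on the ring para to a methyl group, does not treat the two aromatic rings as interchangeable, although the five-membered ring with 2 hetero atoms still leaves a measurable inhibitory concentration. Nothing available explains why the number moves in this direction.

This single pair changes ring size, hetero atom count and the added methyl group together, so it cannot show which of these carries the step. A plain phenyl ring or a pyrazolyl ring without the methyl group at this site would begin to separate them.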